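Adding a 4-Chlorophenyl Group to an Amide Nitrogen

The source may report more compounds than this note shows. Statements on the series, on what has been measured and on what is new or still open speak of the compounds shown alone.

Of the compounds shown here, three sharing a thioxo-containing core have been measured in a functional assay on U-251 cells (Homo sapiens) for inhibition, read by sulforhodamine B assay, with a stated time of 48 h; a lower number here means a stronger inhibitor of growth, a higher number a weaker inhibitor of growth. Compound 1 `O=CN1CCN(c2ccc(Cl)cc2)C1=S` gives 14400 nM. Compound 3 `O=CN1CCN(C(=O)c2ccco2)C1=S` gives 14100 nM. Compound 2 `N#C/C(=C\N1CCN(C(=O)c2ccco2)C1=S)C(N)=O` gives 11500 nM, the lowest of the three numbers, although its gaps to compound 3 and to compound 1 both lie within the usual scatter of repeated measurements, so the three cannot be ranked against one another.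

The unmeasured compound 4 `N#C/C(=C\N1CCN(C(=O)c2ccco2)C1=S)C(=O)Nc1ccc(Cl)cc1` is built from compound 2 by a single change: 4-chlorophenyl in place of hydrogen on an amide-type nitrogen. Among the compounds with values here, no pair of measured compounds shows this particular change, so there is no measured step to lean on; the three values simply show that this core sits in the weak range of this assay whichever group is carried.

With nothing in the measured set to point to a large shift, the expectation for compound 4 is a modest move toward a lower number, a 1.9-fold lower number from compound 2 to compound 4 (0.28 log units; within the scatter), with a real chance of no change beyond the scatter. The estimated value for compound 4 is 6000 nM, in a range from 1500 nM to 20000 nM.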

Compound 4, concentration for 50% growth inhibition: 17300 nM
Beside the measured number, compound 4's estimate is 2.9-fold (0.46 log units) below it; low and high end bracket the measured number.
By their numbers in this assay, from the lowest: compounds 2, 3, 1 and 4 (each within the scatter of the next).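

In this assay, 4-chlorophenyl in place of hydrogen on an amide-type nitrogen gives a 1.5-fold higher number from compound 2 to compound 4 (0.18 log units; within the scatter). Within the data shown here, this is the first comparison in the set that isolates a single change, and it shows that this nitrogen can carry the 4-chlorophenyl group with no shift that can be told apart from repeat measurement, whereas the earlier compounds showed only that values stayed in one weak range. Nothing measured here offers an explanation for this result.

Still open, on these data alone, is whether any other group on this nitrogen would move the number beyond the scatter, such as a plain phenyl ring without the chlorine, a methyl group, or a longer chain ending in an amine. Also open, as far as these compounds go, is whether 4-chlorophenyl would behave the same way on a different core.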